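A Pyrazolyl Amino Group Replaces a Two-Ring Group

The compounds below may be only part of what the source reports. "The series", "measured", "known", "first", "only" and "open" are said of these compounds alone.

Measured so far in an ADME assay on the whole organism (Rattus norvegicus) for pharmacokinetics; a lower number here means that more of the compound stays in the plasma, a higher number that more of the compound sits outside the plasma
compound 1 `CN(c1ncco1)c1cnc(NCc2c(F)ccc3c2CCO3)n2cnnc12` gives 3.1 L/kg
compound 2 `O=C1c2ccccc2CN1c1cnc(NCc2c(F)ccc3c2CCO3)n2cnnc12` gives "not determined" (no result reported)

Compound 2 stands without a number on this scale, since its entry reads "not determined" (no result reported) and no result was reported. Among the measured compounds shown here, it therefore cannot be ranked against anything, and no step starting from it can be sized. For the measured compounds named here, the one number available belongs to compound 1, which gives 3.1 L/kg in this assay and serves as the only reference point.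

The next compound to be measured is compound 3 `CN(c1ccn(C)n1)c1cnc(NCc2c(F)ccc3c2CCO3)n2cnnc12` and it keeps the shared core. The structural change a group of 8 heavy atoms (5 carbon, 3 nitrogen; one five-membered aromatic ring with 2 hetero atoms) in place of a group of 10 heavy atoms (8 carbon, 1 nitrogen, 1 oxygen; one five-membered non-aromatic ring with 1 hetero atom, one six-membered aromatic ring of carbon only), on an aromatic carbon removes a group holding one five-membered non-aromatic ring and one six-membered aromatic ring of carbon only. In its place, on the same aromatic carbon, comes methyl(1-methyl-1H-pyrazol-3-yl)amino.

Compound 1 at 3.1 L/kg is the sole anchor, so in this assay no step beyond the usual scatter is expected for compound 3 in either direction. For compound 3 the estimate is 3 L/kg with an expected range from 1.4 L/kg to 6 L/kg around that figure.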

Compound 3, volume of distribution at steady state: 3 L/kg
Estimate against measurement, compound 3: no gap at the digits printed, and the stated range covers the measured number.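

Placing 1-methyl-1H-pyrazol-3-yl where 1,3-oxazol-2-yl stood on the nitrogen gives, in this assay, a 1.0-fold lower number from compound 1 to compound 3 (0.01 log units; within the scatter). Among the compounds shown here, this is the first readable step at this position, and it shows that these two five-membered aromatic rings can stand in for one another there without moving this read-out beyond the usual scatter, even though the methyl on the ring is new. The step involving compound 2 cannot be read, so its two-ring group stays outside the comparison, and nothing available explains why the number holds steady across this change.

The compounds shown cover only two five-membered aromatic rings on a methyl-bearing nitrogen, so a single step says little about how wide this tolerance is. As far as these compounds go, whether a six-membered ring such as pyridine on that nitrogen, or a carboxylic acid or an amine carried on the pyrazole ring, would shift the distribution of the compound between plasma and the rest of the body remains open.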